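The compounds below may be only part of what the source reports. "The series", "measured", "known", "first", "only" and "open" are said of these compounds alone.

Series notes. Compound 3 `COc1cc(-c2nn(-c3cccc(NC(=O)Nc4ccc(Cl)c(Cl)c4)c3)cc2-c2ccncc2)ccc1Cl` carries a methoxy on its aryl ring and a dichlorophenyl urea. In a functional assay on M14 cells (Homo sapiens) for inhibition, read by sulforhodamine B assay, with a stated time of 48 h (a higher number here means a weaker inhibitor of growth, a lower number a stronger inhibitor of growth), compound 3 gives 2690 nM, the lowest of the two numbers recorded so far. Its nearest neighbour in this assay is compound 1 `O=C(Nc1cccc(-n2cc(-c3ccncc3)c(-c3ccc(Cl)c(O)c3)n2)c1)Nc1cccc(C(F)(F)F)c1`, and in this assay compound 1 gives 10800 nM. Compound 2 `COc1cc(-c2nn(-c3cccc(NC(=O)c4cccc(C(F)(F)F)c4)c3)cc2-c2ccncc2)ccc1Cl` in this assay gives only a limit, > 50000 nM. For the measured compounds named here, the one measured step rests on that limit of > 50000 nM in this assay, at which 1 of the 3 values shown sits, and concerns the carbonyl carbon: an at least 18-fold lower number from compound 2 to compound 3 (1.26 log units; beyond the scatter). Compound 4 `O=C(Nc1cccc(-n2cc(-c3ccncc3)c(-c3ccc(Cl)c(O)c3)n2)c1)Nc1ccc(Cl)c(Cl)c1` is the compound still to be measured; it differs from compound 3 by hydrogen in place of methyl on an oxygen on an aromatic ring. Going by the values given here, no measured step in this assay covers this change on its own: compound 1 and compound 2 differ both at the oxygen and at the carbonyl carbon, so their two values cannot be split between the two changes, and the single measured step concerns the other site. The change from compound 3 to compound 4 is therefore expected to be modest, with a step of a 1.3-fold higher number from compound 3 to compound 4 (0.11 log units; within the scatter) estimated, close to the scatter. Compound 4 is expected in this assay to give about 3500 nM, with a range from 1200 nM to 10000 nM.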

Compound 4, concentration for total growth inhibition: 6970 nM
The estimate for compound 4 lay 2.0-fold (0.30 log units) below the measured number, within the range that was stated.
By their numbers in this assay, from the lowest: compound 3; then compounds 4 and 1 (each within the scatter of the next). At a limit, above all of these: compound 2.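

In this assay, the change from methoxy to hydroxy at this oxygen on the aromatic ring now has a step of its own, with the 3,4-dichlorophenyl urea held fixed: a 2.6-fold higher number from compound 3 to compound 4 (0.41 log units; beyond the scatter), so the methoxy of compound 3 goes with the lower number in this one pair. With the hydroxy held fixed, the group on the amide-type nitrogen gives a 1.5-fold lower number from compound 1 to compound 4 (0.19 log units; within the scatter), so 3,4-dichlorophenyl and 3-(trifluoromethyl)phenyl cannot be told apart on this background. Nothing measured among the compounds shown bears on the cause of either step.

As far as these compounds go, whether the methoxy to hydroxy step keeps its size with a group other than 3,4-dichlorophenyl on the urea stays open, as this change is read in a single pair. Also open, from the compounds shown here alone, is how an ethoxy, a longer alkoxy chain, an amine or a carboxylic acid at this place on the aromatic ring would compare with the hydroxy and methoxy of compound 4 and compound 3.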